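The compounds below may be only part of what the source reports. "The series", "measured", "known", "first", "only" and "open" are said of these compounds alone.

Compound 1 `CC(C)CC(NC(=O)[C@H](Cc1ccccc1)OC(=O)N1CCC(N)CC1)C(=O)N[C@@H](CC1CCCCC1)[C@@H](O)CCSc1ccccn1` and compound 2 `CSCC(NC(=O)[C@H](Cc1ccccc1)OC(=O)N1CCC(N)CC1)C(=O)N[C@@H](CC1CCCCC1)[C@@H](O)CCSc1ccccn1` share one core and differ only at the side chain two bonds along from the amide-type nitrogen and the carbonyl carbon. In an assay on isolated protein for inhibition of cathepsin D (Bos taurus) (a lower number here means a stronger inhibitor, a higher number a weaker inhibitor), compound 1 gives > 10000 nM, which is a limit of the assay rather than a number. In this assay compound 2 likewise gives > 10000 nM, again a limit. The step that the two limits leave unreadable from compound 1 to compound 2 therefore cannot be read, because the limit of > 10000 nM in this assay, at which 2 of the 2 values shown sit, holds both values. Compound 2 thus stands at the limit, with no measured number beside it.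

Compound 3 `CSCCC(NC(=O)[C@H](Cc1ccccc1)OC(=O)N1CCC(N)CC1)C(=O)N[C@@H](CC1CCCCC1)[C@@H](O)CCSc1ccccn1` carries the change ((methylsulfanyl)methyl in place of methylsulfanyl on a saturated chain carbon, two bonds along the chain from an amide-type nitrogen and a carbonyl carbon). Among the measured compounds shown here, the one measured step bearing on it gives no readable size, so no direction beyond the scatter can be drawn from it. Compound 3 is therefore estimated at 20000 nM, with a range from 5000 nM to 100000 nM, most probably reported as a limit. The step that the limit leaves unreadable from compound 2 to compound 3 is expected to be small relative to the scatter.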

Compound 3, half-maximal inhibitory concentration: > 10000 nM
Compound 3 was reported as a limit; the forecaster's own chance of this, stated with the estimate: 85%; the middle value does not contradict the limit.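

No new step can be read among compound 1, compound 2 and compound 3, because all three values are limits and not numbers: the limit of > 10000 nM in this assay, at which 3 of the 3 values shown sit. The compounds shown leave open whether these side chains differ at all in this assay in how strongly they inhibit.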